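A non-aromatic ring replaces 4-cyanophenyl on the oxygen

A few compounds are considered here, and "the series" means these few. Any claim that something is new, unique, unknown or untested is made for them only; others in the source may bear on it.

Measured so far in a functional assay on MX1 cells (Homo sapiens) for antiproliferative activity, with a stated time of 72 h (on this read-out lower numbers stand for an effect already at smaller amounts and higher numbers for an effect only at larger amounts of compound), are three compounds:
- compound 1 `CCS(=O)(=O)Nc1ccc(Oc2ccc(C#N)cc2)c(-c2cn(C)c(=O)c3[nH]ccc23)c1` with 17 nM
- compound 2 `Cn1cc(-c2cc(NS(C)(=O)=O)ccc2Oc2ccccc2C(F)(F)F)c2cc[nH]c2c1=O` with 83 nM
- compound 3 `Cn1cc(-c2cc(NS(C)(=O)=O)ccc2OC2CCC(F)(F)CC2)c2cc[nH]c2c1=O` with 19 nM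

Compound 1 sits at the low end of these numbers, together with compound 3, and the two values lie within the usual scatter of each other. Compound 2 stands clearly higher than both.

The next compound is compound 4 `CCS(=O)(=O)Nc1ccc(OC2CCN(C)CC2)c(-c2cn(C)c(=O)c3[nH]ccc23)c1`, and its difference from compound 1 is 1-methylpiperidin-4-yl in place of 4-cyanophenyl on an oxygen on an aromatic ring. Among the measured compounds shown here, one measured step bears on this change, a 4.4-fold lower number from compound 2 to compound 3 (0.64 log units; beyond the scatter), where 4,4-difluorocyclohexyl took the place of 2-(trifluoromethyl)phenyl at the same kind of place. That modest step points to a non-aromatic ring being tolerated there, yet it starts from a different aromatic group. For the measured compounds named here, no measured compound carries a nitrogen in the ring on that oxygen, so the guide is loose. A modest rise is therefore expected, though none beyond the scatter remains possible. The expected step is a 2.9-fold higher number from compound 1 to compound 4 (0.47 log units; beyond the scatter) as an estimate only. For compound 4 the estimated value is 50 nM with 15 nM to 180 nM as the expected range.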

Compound 4, half-maximal effective concentration: 210 nM
Estimate against measurement, compound 4: 4.2-fold (0.62 log units) below, and the stated range ends below it.
By their numbers in this assay, from the lowest: compounds 1 and 3 (each within the scatter of the next); then compound 2; then compound 4.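

In this assay the change from 4-cyanophenyl to 1-methylpiperidin-4-yl on this oxygen gives a 12-fold higher number from compound 1 to compound 4 (1.09 log units; beyond the scatter) and so counts as a large step. This shows that a non-aromatic ring at this place does not by itself fix the direction of the change: the earlier step with 4,4-difluorocyclohexyl, a 4.4-fold lower number from compound 2 to compound 3 (0.64 log units; beyond the scatter), went the other way, although it started from 2-(trifluoromethyl)phenyl and not from 4-cyanophenyl. Nothing measured here accounts for the rise seen with compound 4.

The compounds shown leave open whether the rise goes with the ring nitrogen, with the methyl on it, or simply with the loss of 4-cyanophenyl. A plain cyclohexyl, a tetrahydropyran-4-yl and an unsubstituted piperidin-4-yl on the same oxygen of the core of compound 1 would separate these three readings, and 4,4-difluorocyclohexyl on that same core would allow a direct comparison with 4-cyanophenyl.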